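The source may hold more compounds than are shown below. What is called first, only, known or untested is meant among the compounds shown, and "the series" means these compounds.

Measured so far in a functional assay for inhibition of sodium/hydrogen exchanger (Oryctolagus cuniculus); on this read-out higher numbers stand for weaker inhibition and lower numbers for stronger inhibition:
compound 3 `CCCSc1cc(C)c(C(=O)N=C(N)N)cc1S(C)(=O)=O` gives 6.8 nM;
compound 1 `CCc1cc(Br)c(S(C)(=O)=O)cc1C(=O)N=C(N)N` gives 41 nM;
compound 2 `CS(=O)(=O)c1cc(C(=O)N=C(N)N)c(Cl)cc1Cl` gives 140 nM.

Compound 3 has the lowest number of the three, and its gaps to compound 1 and to compound 2 both lie beyond the usual scatter, so it is the strongest inhibitor shown here. The path to compound 4 `Cc1cc(Oc2ccc(Cl)cc2)c(S(C)(=O)=O)cc1C(=O)N=C(N)N` alters one place on the shared core: 4-chlorophenoxy in place of propylsulfanyl on an aromatic carbon. Among the measured compounds shown here, no measured pair shows this exchange, so its effect is unknown. Because compound 3 already stands at 6.8 nM, only a modest move toward weaker inhibition is expected, a 2.2-fold higher number from compound 3 to compound 4 (0.34 log units; beyond the scatter), near the edge of the scatter. Compound 4 is therefore estimated at 15 nM, with a likely range from 4 nM to 60 nM in this assay.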

Compound 4, half-maximal inhibitory concentration: 13 nM
For compound 4 the middle estimate is 1.2-fold (0.06 log units) above the measured one; measured number inside the range.
By their numbers in this assay, from the lowest: compounds 3 and 4 (each within the scatter of the next); then compound 1; then compound 2.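

In this assay the step reads a 1.9-fold higher number from compound 3 to compound 4 (0.28 log units; within the scatter), so this position, on an aromatic carbon ortho to a methylsulfonyl group, takes the larger 4-chlorophenoxy group, with its aromatic ring, and the two compounds cannot be told apart. The earlier compounds shown here did not show that a ringed group and an open chain can sit here with matching numbers. No measurement at hand offers an explanation for this result.

Still open, from the compounds shown here alone, is what the chlorine on the ring contributes, as plain phenoxy is absent from these compounds. A basic amine or a carboxylic acid at this position also remains untested among the compounds shown.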